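The compounds below may be only part of what the source reports. "The series", "measured", "known", "first", "only" and "open" are said of these compounds alone.

Measured compounds:

Compound 1, `COc1cc(-c2nnc3n2NC(c2ccco2)C(C(=O)c2ccco2)S3)cc(OC)c1OC`, in a functional assay on PC-3 cells (Homo sapiens) for cytotoxicity, read by MTT assay, with a stated time of 48 h (a lower number here means a stronger inhibitor, a higher number a weaker inhibitor), gives 58300 nM.
Compound 2, `COc1cc(-c2nnc3n2NC(c2ccco2)C(C(=O)c2cccs2)S3)cc(OC)c1OC`, in this assay gives 46200 nM.
Compound 3, `COc1cc(-c2nnc3n2NC(c2ccco2)C(C(=O)c2ccccc2C)S3)cc(OC)c1OC`, in this assay gives 88400 nM.

Compound 3 carries the largest of the three numbers, but its distance from the others is small: the step of a 1.5-fold higher number from compound 1 to compound 3 (0.18 log units; within the scatter) and the step of a 1.9-fold higher number from compound 2 to compound 3 (0.28 log units; within the scatter) both lie within the scatter, as does the step of a 1.3-fold lower number from compound 1 to compound 2 (0.10 log units; within the scatter). Across these three compounds, exchanging the aryl group on the carbonyl carbon has therefore produced no change that can be told from repeat measurement.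

Compound 4, `COc1cc(-c2nnc3n2NC(c2ccco2)C(C(=O)c2cccc4ccccc24)S3)cc(OC)c1OC`, differs from compound 3 by naphthalen-1-yl in place of 2-methylphenyl on a carbonyl carbon. All three measured steps bear on this change, since each also swaps the group on the same carbonyl carbon, and each was within the scatter. Among the compounds with values here, a larger aromatic system enters here, which none of the measured pairs covers, so the expectation rests on the flat pattern alone. Compound 4 is therefore expected to show a step of a 1.0-fold lower number from compound 3 to compound 4 (0.02 log units; within the scatter), that is, no step beyond the scatter. Compound 4 is estimated at 85000 nM, with a range from 40000 nM to 180000 nM.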

Compound 4, half-maximal inhibitory concentration: > 100000 nM
Compound 4 ended at the assay's limit; the forecaster's own chance of this, stated with the estimate: 15%; middle value at least 1.1-fold (0.07 log units) from the limit.
By their numbers in this assay, from the lowest: compounds 2, 1 and 3 (each within the scatter of the next). At a limit, above all of these: compound 4.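

Compound 4 has no number in this assay, only a limit of the assay: the limit of > 100000 nM in this assay, at which 1 of the 4 values shown sits. Even so, the group on this carbonyl carbon now shows an effect that can be told from repeat measurement, since naphthalen-1-yl in place of thiophen-2-yl gives an at least 2.1-fold higher number from compound 2 to compound 4 (0.33 log units; beyond the scatter), the only step among those shown to pass the scatter. The other two, an at least 1.1-fold higher number from compound 3 to compound 4 (0.05 log units; that floor lies within the scatter) and an at least 1.7-fold higher number from compound 1 to compound 4 (0.23 log units; that floor lies within the scatter), are floors only, so the true distance of compound 4 from compound 3 and from compound 1 cannot be read.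

As far as these compounds go, it remains open whether a group of another kind on this carbonyl carbon, such as a carboxylic acid or an amine on a longer chain, would move the number in the opposite direction. The compounds shown also do not tell whether a smaller group than these aryl rings, such as methyl, would change the number at all.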